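A few compounds are considered here, and "the series" means these few. Any claim that something is new, unique, unknown or untested is made for them only; others in the source may bear on it.

Measured compounds:
Compound 1, `CCN(CC)C(=O)c1ccccc1OCC1=NCCN1`, in a functional assay for activation of Alpha-1A adrenergic receptor (Homo sapiens), read by calcium flux (on this read-out higher numbers stand for an effect only at larger amounts of compound and lower numbers for an effect already at smaller amounts), gives a value that is only a limit of the assay, < 5020 nM.
Compound 2, `c1cnc(-c2ccccc2OCC2=NCCN2)nc1`, gives 1260 nM in this assay.
Compound 3, `c1ccc(-c2ccoc2)c(OCC2=NCCN2)c1`, gives 0.501 nM in this assay.

Within the data shown here, compound 3 sits at the lowest of the two numbers that are not limits, far apart from compound 2: the step of a 2500-fold lower number from compound 2 to compound 3 (3.40 log units; beyond the scatter) is the only measured step here, and it is large. Compound 4, `Cc1ccc(-c2ccccc2OCC2=NCCN2)s1`, is compound 3 with a single change: 5-methylthiophen-2-yl in place of furan-3-yl on an aromatic carbon. This is one five-membered aromatic ring with one hetero atom replaced by another of the same kind, whereas the measured step from compound 2 to compound 3 exchanged a six-membered ring with two nitrogens for a five-membered one. That step therefore says little about the present change beyond showing that the ring at this place matters. Among the measured compounds shown here, with no closer precedent, the expectation for compound 4 is a step that stays near the scatter, a 2.0-fold higher number from compound 3 to compound 4 (0.30 log units; within the scatter). The estimate for compound 4 in this assay is 1 nM, within 0.2 nM to 6 nM.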

Compound 4, half-maximal effective concentration: 25.1 nM
Compound 4: middle estimate off by 25-fold (1.40 log units), on the low side, and the stated range ends below it.
By their numbers in this assay, from the lowest: compound 3; then compound 4; then compound 2.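

In this assay, the earlier step showed only that a pyrimidin-2-yl and a furan-3-yl differ widely at this place. The change to 5-methylthiophen-2-yl gives a 50-fold higher number from compound 3 to compound 4 (1.70 log units; beyond the scatter), so even two groups that are each one five-membered aromatic ring with 1 hetero atom are not interchangeable here. The same group still stands well apart from pyrimidin-2-yl, with a 50-fold lower number from compound 2 to compound 4 (1.70 log units; beyond the scatter), which places compound 4 in the wide gap between the other two compounds and shows that this position responds in graded steps. Nothing measured here gives a reason for either step.

On these data alone, this single change alters the hetero atom, the point of attachment and the methyl group all at once, so the share of each stays unknown. As far as these compounds go, it remains open whether a plain thiophen-2-yl without the methyl, or a furan-2-yl, would sit nearer compound 3 or compound 4.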